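The source may report more compounds than this note shows. Statements on the series, on what has been measured and on what is new or still open speak of the compounds shown alone.

Of the compounds shown here, two have been measured in a functional assay on NCI-H460 cells (Homo sapiens) for inhibition, read by MTT assay, with a stated time of 24 h, tested at 1 ug/mL; a lower number here means less inhibition of growth, a higher number more inhibition of growth at the concentration tested. Compound 1 (`CC(=O)SCCC(CCCCC(=O)O)SC(C)=O`) gives 9.89% in this test and compound 2 (`O=C(CCCCC1CCSS1)Nc1cccc(C(F)(F)F)c1`) gives 4.39% in the same test. These two values lie within the usual scatter of each other, which means compound 2 cannot be told apart from compound 1 on these numbers.

Compound 3 (`O=C(CCCCC1CCSS1)Nc1ccc([N+](=O)[O-])c(C(F)(F)F)c1`) is compound 2 with one change (nitro in place of hydrogen on an aromatic carbon). A nitro group takes the place of a hydrogen on an aromatic carbon, ortho to a trifluoromethyl group and para to a large group. For the measured compounds named here, no measured pair of compounds shows what this change does, and the two structures in hand differ in more than one place. Going by the values given here, the only guide is the low reading of compound 2 (4.39%), and a small upward step is expected in this assay, none beyond the scatter. The estimated step (a number 3.6 percentage points higher from compound 2 to compound 3 (within the scatter)) reflects this expectation. For compound 3 the expected value is 8% within an estimated range from 0% to 22% in this test.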

Compound 3, percent growth inhibition at one concentration: 19.1%
Estimate against measurement, compound 3: 11.1 percentage points below; the range from low to high includes it.
By their numbers in this assay, from the lowest: compounds 2, 1 and 3 (each within the scatter of the next, the first and the last beyond it).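

In this assay, the aromatic carbon ortho to a trifluoromethyl group and para to a large group turns out to be a place where a single change registers: nitro in place of hydrogen gives a number 14.7 percentage points higher from compound 2 to compound 3 (beyond the scatter) and is a modest step. The earlier compounds shown here could not show this, since they differ in more than one place and their values lie within the scatter of each other, whereas this pair differs in one place only and ties the change in the number to this position. No measurement bearing on this step is available to explain it.

From the compounds shown here alone, whether the step belongs to nitro itself or would also appear with an amine, a nitrile or a carboxylic acid on the same carbon remains open, as does whether it depends on the neighbouring trifluoromethyl group. The compounds shown also leave open what a longer chain on the amide carbonyl would do, and whether the step would hold at another concentration or exposure time.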